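Allyl in Place of a Hydroxyl Hydrogen: an Expected Step

The source may report more compounds than this note shows. Statements on the series, on what has been measured and on what is new or still open speak of the compounds shown alone.

Of the compounds shown here, two sharing one core have been measured in a functional assay on liver (Rattus norvegicus, strain Sprague-Dawley) for inhibition, with a stated time of 1 h; on this read-out higher numbers stand for weaker inhibition and lower numbers for stronger inhibition. Compound 1 `C=CCOc1cc(O)c2c(=O)c(O)c(-c3ccc4c(c3)OC(c3ccc(OCC=C)c(OC)c3)C(CO)O4)oc2c1` gives 22600 nM, the higher of the two numbers and so the weaker inhibitor of the pair. Compound 2 `CCN(CC)C(=O)COc1cc(O)c2c(=O)c(O)c(-c3ccc4c(c3)OC(c3ccc(OCC(=O)N(CC)CC)c(OC)c3)C(CO)O4)oc2c1` gives 5800 nM, a lower number whose gap from compound 1 lies beyond the usual scatter; the two differ in more than one place, so that gap says nothing about any single change. Compound 3 `C=CCOc1cc(O)c2c(=O)c(OCC=C)c(-c3ccc4c(c3)OC(c3ccc(OCC=C)c(OC)c3)C(CO)O4)oc2c1` has not been measured. It differs from compound 1 in one place: allyl in place of hydrogen on an oxygen on an aromatic ring. For the measured compounds named here, no measured pair shows this change, so there is no direct precedent. Putting an allyl on this oxygen is expected to matter little, and the step of a 1.4-fold higher number from compound 1 to compound 3 (0.15 log units; within the scatter) is estimated to be modest, leaning toward weaker inhibition and close to the scatter. Compound 3 is therefore expected to give about 32000 nM, within a range from 10000 nM to 100000 nM.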

Compound 3, half-maximal inhibitory concentration: 54800 nM
Compound 3: the middle estimate sits 1.7-fold (0.23 log units) below what was measured; measured number inside the range.
By their numbers in this assay, from the lowest: compound 2; then compound 1; then compound 3.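

Compounds 1 and 2 both carry a free hydroxy on this oxygen on an aromatic ring, so neither could show whether the position tolerates a group there. In this assay the change from hydroxy to allyloxy gives a 2.4-fold higher number from compound 1 to compound 3 (0.38 log units; beyond the scatter) and this step lies beyond the usual scatter, so inhibition does respond to what sits on this oxygen, and allyl here goes with weaker inhibition rather than stronger. Nothing measured here accounts for the direction or size of this step.

As far as these compounds go, whether the weakening is particular to allyl or follows from any group on this oxygen stays open, and a methyl, a longer chain or a chain ending in a carboxylic acid would help to separate these. From the compounds shown here alone, what the same change would do when it starts from compound 2 also remains unknown.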